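The source may report more compounds than this note shows. Statements on the series, on what has been measured and on what is new or still open speak of the compounds shown alone.

Going by the values given here, in a functional assay on HeLa cells (Homo sapiens) for cytotoxicity, read by MTT assay, with a stated time of 2 days (on this read-out lower numbers stand for stronger inhibition and higher numbers for weaker inhibition), compound 1 `Cc1cccc(-c2nc3cc(C)ccc3c(=O)[nH]2)c1` gives 11200 nM, the only true number available so far. Compound 2 `Cc1cccc(-c2nc3ccc(C)cc3c(=O)[nH]2)c1` is recorded at > 50000 nM, which is a limit of the assay and not a number. Compound 1 therefore gives the one firm reference point for what follows.

Compound 3 `Cc1ccc2c(=O)[nH]c(-c3cccc(C(F)(F)F)c3)nc2c1` keeps the core of compound 1 but carries trifluoromethyl in place of methyl on an aromatic carbon, meta to a large group: trifluoromethyl in place of methyl on an aromatic carbon. Among the compounds with values here, no measured pair of compounds shows what this exchange does, so the data offer no direct guide to its size or direction. The cautious expectation in this assay is therefore no step beyond the usual scatter, and the expected change is a 1.3-fold higher number from compound 1 to compound 3 (0.13 log units; within the scatter). For compound 3 the estimated value is 15000 nM, with an expected range from 5000 nM to 50000 nM.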

Compound 3, half-maximal inhibitory concentration: > 50000 nM
Compound 3 ended at the assay's limit (the forecaster's own chance of this, stated with the estimate: 20%); middle value at least 3.3-fold (0.52 log units) away from the limit.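

Trifluoromethyl in place of methyl on this aromatic carbon, meta to a large group, gives an at least 4.4-fold higher number from compound 1 to compound 3 (0.64 log units; beyond the scatter). Going by these compounds alone, this is the first sign that the group at this position affects the read-out, and the change points toward weaker inhibition, which no earlier pair of compounds could show. Compound 3 stands at a limit of this assay and not at a number, so the direction and a smallest size can be read, but the true step may be larger, because the scale ends there: the limit of > 50000 nM in this assay, at which 2 of the 3 values shown sit.

Within the data shown here, with only one exchange at this position, the step gives no trend across groups. As far as these compounds go, it remains open whether a chlorine atom, a methoxy group or an amine at this position would raise or lower the number of compound 1.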